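Working notes: from compound 3 to compound 4

The source may hold more compounds than are shown below. What is called first, only, known or untested is meant among the compounds shown, and "the series" means these compounds.

Values in a functional assay on MCF7 cells (Homo sapiens) for inhibition, read by sulforhodamine B assay (on this read-out lower numbers stand for stronger inhibition of growth and higher numbers for weaker inhibition of growth), so far
- compound 1 `COc1cc(-c2ccc(-c3ccc(-c4nc5cc(C)ccc5[nH]4)cc3)cc2)cc(OC)c1OC` gives 170 nM 
- compound 2 `FC(F)(F)Oc1ccc(-c2ccc(-c3ccc(-c4nc5ccccc5[nH]4)cc3)cc2)cc1` gives 38400 nM 
- compound 3 `Oc1ccc(-c2ccc(-c3ccc(-c4nc5ccccc5[nH]4)cc3)cc2)cc1` gives 30500 nM 

Compound 3 sits within the scatter of compound 2, and both lie far above compound 1. Next comes compound 4 `COc1ccc(-c2ccc(-c3ccc(-c4nc5ccccc5[nH]4)cc3)cc2)cc1OC` with the change 3,4-dimethoxyphenyl in place of 4-hydroxyphenyl on an aromatic carbon on an aromatic carbon. For the measured compounds named here, the one measured step at this place, a 1.3-fold lower number from compound 2 to compound 3 (0.10 log units; within the scatter), stays within the scatter and gives no direction. Compound 1 gives 170 nM and also carries methoxy groups, but its core differs too, so it is only a loose guide. A drop in this assay is therefore expected, smaller than the gap to compound 1. The expected step is a 10-fold lower number from compound 3 to compound 4 (1.01 log units; beyond the scatter) and it remains uncertain. Compound 4 is estimated at 3000 nM with 400 nM to 25000 nM as the expected range.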

Compound 4, concentration for 50% growth inhibition: 7600 nM
Beside the measured number, compound 4's estimate is 2.5-fold (0.40 log units) below it, within the range that was stated.
By their numbers in this assay, from the lowest: compound 1; then compound 4; then compounds 3 and 2 (each within the scatter of the next).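

In this assay, for the compounds shown here, the exchange of 4-hydroxyphenyl for 3,4-dimethoxyphenyl gives a 4.0-fold lower number from compound 3 to compound 4 (0.60 log units; beyond the scatter), the first step at this position beyond the scatter, whereas a 1.3-fold lower number from compound 2 to compound 3 (0.10 log units; within the scatter) gave no direction. The aromatic group at this position can therefore shift growth inhibition, though only modestly here. No measured property bears on the size of this step.

Going by these compounds alone, the single exchange does not separate the loss of the hydroxyl from the gain of the two methoxy groups. On these data alone, how an amine or a carboxylic acid on this ring would read out remains open.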